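Methyl in Place of Nitro and Cell Toxicity

The source may hold more compounds than are shown below. What is called first, only, known or untested is meant among the compounds shown, and "the series" means these compounds.

Compound 1 `O=c1cc(CNCc2cccc([N+](=O)[O-])c2)oc2ccc(O)c(O)c12` and compound 2 `Cc1cccc(CNCc2cc(=O)c3c(O)c(O)ccc3o2)c1` differ only by methyl in place of nitro on an aromatic carbon. In an ADME assay on Huh-7 cells (Homo sapiens) for cytotoxicity (on this read-out lower numbers stand for higher toxicity in this test and higher numbers for lower toxicity in this test), compound 1 reaches only a limit of the assay, > 100000 nM. In this assay compound 2 likewise reaches only a limit, > 100000 nM. The step that the two limits leave unreadable from compound 1 to compound 2 cannot be sized because of the limit of > 100000 nM in this assay, at which 2 of the 3 values shown sit. Compound 3 `O=c1cc(CNCc2ccc([N+](=O)[O-])cc2)oc2ccc(O)c(O)c12` has the same atoms as compound 1 joined differently; the difference between the two cores is not broken down here. In this assay compound 3 gives 73300 nM. Compound 4 `Cc1ccc(CNCc2cc(=O)c3c(O)c(O)ccc3o2)cc1` arises from compound 3 by methyl in place of nitro on an aromatic carbon, the same kind of change as before, though here the group sits para to a large group rather than meta to a large group. The step from compound 3 to compound 4 is expected to be a 1.6-fold higher number from compound 3 to compound 4 (0.21 log units; within the scatter). That expectation rests on compound 2, which in this assay gives only a limit, > 100000 nM. For compound 4 the estimated value is 120000 nM.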

Compound 4, half-maximal cytotoxic concentration: > 100000 nM
Compound 4: only a limit was reported (the forecaster's own chance of this, stated with the estimate: 65%); the middle value lies beyond the limit too.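

Where methyl replaces nitro para to a large group, the result is an at least 1.3-fold higher number from compound 3 to compound 4 (0.13 log units; that floor lies within the scatter) in this assay. Compound 4 gives > 100000 nM, which is a limit of the assay and not a number, so this step is only a floor and does not establish a true rise. The same change on the core of compound 1 and the step between compound 2 and compound 4 cannot be read, so whether the change carries over from one core to the other stays unknown, because of this: the limit of > 100000 nM in this assay, at which 3 of the 4 values shown sit.

The compounds shown leave open how an amine or a carboxylic acid in place of the nitro would read in this assay. They also leave open how far compound 2 and compound 4 lie beyond the limit.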